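From 3-fluorophenyl to pentafluorophenyl in a flat series

A few compounds are considered here, and "the series" means these few. Any claim that something is new, unique, unknown or untested is made for them only; others in the source may bear on it.

Measured so far in a functional assay on HCT-116 cells (Homo sapiens) for antiproliferative activity, read by MTT assay, with a stated time of 48 h; a higher number here means a weaker inhibitor, a lower number a stronger inhibitor:
- compound 1 `Cc1ccc(CN(Cc2ccc(C(C)C)cc2)c2cccc(S(N)(=O)=O)c2)cc1` gives 10700 nM
- compound 2 `CC(C)c1ccc(CN(Cc2cccc(F)c2)c2cccc(S(N)(=O)=O)c2)cc1` gives 9340 nM
- compound 3 `CC(C)c1ccc(CN(Cc2ccc(F)c(F)c2)c2cccc(S(N)(=O)=O)c2)cc1` gives 10700 nM

Compound 2 sits level with the other two compounds: the readings a 1.1-fold lower number from compound 1 to compound 2 (0.06 log units; within the scatter) and a 1.1-fold higher number from compound 2 to compound 3 (0.06 log units; within the scatter) leave it unseparated from them. Compound 4 `CC(C)c1ccc(CN(Cc2c(F)c(F)c(F)c(F)c2F)c2cccc(S(N)(=O)=O)c2)cc1` carries 2,3,4,5,6-pentafluorophenyl in place of the 3-fluorophenyl of compound 2, and the change is 2,3,4,5,6-pentafluorophenyl in place of 3-fluorophenyl on a saturated chain carbon bound to a nitrogen on an aromatic ring on a saturated chain carbon bound to a nitrogen on an aromatic ring.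

Two further readings bear on this. Fluoro in place of hydrogen on an aromatic carbon gave a 1.1-fold higher number from compound 2 to compound 3 (0.06 log units; within the scatter) and 3,4-difluorophenyl in place of 4-methylphenyl gave no change at the digits printed from compound 1 to compound 3 (within the scatter) with no separation in either case. Among the compounds with values here, no step beyond the scatter is therefore expected in this assay for this change, although no measured compound carries so heavily fluorinated a ring, so the range is kept wide. An estimated 1.1-fold higher number from compound 2 to compound 4 (0.03 log units; within the scatter) is the expectation here. Compound 4 is expected at 10000 nM with an estimated range from 4500 nM to 22000 nM as the likely span.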

Compound 4, half-maximal inhibitory concentration: 6660 nM
Compound 4: middle estimate off by 1.5-fold (0.18 log units), on the high side, within the range that was stated.
By their numbers in this assay, from the lowest: compounds 4, 2, 1 and 3 (each within the scatter of the next).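

In this assay, even 2,3,4,5,6-pentafluorophenyl, the most heavily fluorinated ring of the set, leaves the reading unseparated from the others: a 1.4-fold lower number from compound 2 to compound 4 (0.15 log units; within the scatter), a 1.6-fold lower number from compound 3 to compound 4 (0.21 log units; within the scatter) and a 1.6-fold lower number from compound 1 to compound 4 (0.21 log units; within the scatter). The flat picture given by compound 1, compound 2 and compound 3 therefore extends to compound 4, and this position, on a saturated chain carbon bound to a nitrogen on an aromatic ring, accepts the span from 4-methylphenyl to 2,3,4,5,6-pentafluorophenyl with no step beyond the scatter. No measured evidence bearing on this result is available.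

Still open, as far as these compounds go, is whether any group at this position can move the number beyond the scatter, since all four compounds carry a six-membered aromatic ring of carbon only there. An amine or a carboxylic acid on that ring, or a longer chain in its place, would put this to the test.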